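Removing a methyl from the methoxy of compound 1

The compounds below may be only part of what the source reports. "The series", "measured", "known", "first", "only" and "open" are said of these compounds alone.

Compound 1 `COc1ccc(Br)cc1C(=O)Nc1ccc(Sc2nc3ccccc3s2)cc1`: in an assay for inhibition of HSP60/HSP10 (Homo sapiens), with a stated time of 60 min (on this read-out higher numbers stand for weaker inhibition and lower numbers for stronger inhibition), compound 1 gives > 100000 nM.
Compound 2 `O=C(Nc1ccc(Sc2nc3ccccc3s2)c(Cl)c1)c1cccc(Br)c1O`: in this assay compound 2 gives 6900 nM.

The value of compound 1 is a limit of this assay and not a number, so compound 1 stands only at the limit of > 100000 nM in this assay, at which 1 of the 2 values shown sits. The unmeasured compound 3 `O=C(Nc1ccc(Sc2nc3ccccc3s2)cc1)c1cc(Br)ccc1O` differs from compound 1 in one place: hydrogen in place of methyl on an oxygen on an aromatic ring. Within the data shown here, no step between two measured compounds is available, so the size of this change has to be guessed. Compound 2, which also carries a hydroxy on its benzamide, gives a measured number rather than a limit, and that is all its value shows. The step from compound 1 to compound 3 is expected to go toward stronger inhibition, by an at least 4.0-fold lower number from compound 1 to compound 3 (0.60 log units; beyond the scatter). Compound 3 is accordingly estimated at 25000 nM, within a range from 5000 nM to 100000 nM.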

Compound 3, half-maximal inhibitory concentration: > 100000 nM
Compound 3 ended at the assay's limit; the forecaster's own chance of this, stated with the estimate: 30%; middle value at least 4.0-fold (0.60 log units) from the limit.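

Compound 1 and compound 3 both stand at a limit of this assay and not at a number, so the step between them cannot be read: the limit of > 100000 nM in this assay, at which 2 of the 3 values shown sit.

The compounds shown leave open whether the change from methoxy to hydroxy moves inhibition at all, and by how much.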